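Saturating the indene in a dioxane-fused arylpiperazine series

This account rests on a few compounds, and the source may have more. Where it says the series, first, only, none or still open, it means among the compounds named here.

In an assay for activation of Adrenergic receptor alpha-1 (Rattus norvegicus) (on this read-out lower numbers stand for an effect already at smaller amounts and higher numbers for an effect only at larger amounts of compound), compound 2, `C1=C(CCN2CCN(c3cccc4c3OCCO4)CC2)Cc2ccccc21`, gives 0.17 mg/kg, the lowest of the two numbers shown. Compound 3, `c1ccc2c(c1)CC2CCCCN1CCN(c2cccc3c2OCCO3)CC1`, gives 7.15 mg/kg, a gap well beyond the usual scatter. Compound 1, `c1ccc2c(c1)CCCCC2CCN1CCN(c2cccc3c2OCCO3)CC1`, reaches only a limit of the assay at > 2.5 mg/kg (the limit of > 2.5 mg/kg in this assay, at which 1 of the 3 values shown sits).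

Compound 4, `c1ccc2c(c1)CC(CCN1CCN(c3cccc4c3OCCO4)CC1)C2`, has not yet been measured. It differs from compound 2 in one place: a group of 9 heavy atoms (9 carbon; one five-membered non-aromatic ring of carbon only, one six-membered aromatic ring of carbon only) in place of a group of 9 heavy atoms (9 carbon; one five-membered non-aromatic ring of carbon only, one six-membered aromatic ring of carbon only), on a saturated chain carbon, two bonds along the chain from an amine nitrogen in a ring. The group that leaves carries one double bond outside aromatic rings; the group that enters carries none. For the measured compounds named here, no measured pair shows this change, so any expectation rests on compound 2 alone. A modest rise beyond the scatter is expected, a 2.4-fold higher number from compound 2 to compound 4 (0.37 log units; beyond the scatter), so compound 4 is estimated at 0.4 mg/kg, within 0.12 mg/kg to 1.3 mg/kg.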

Compound 4, dose for half-maximal effect: 0.66 mg/kg
For compound 4 the middle estimate is 1.7-fold (0.22 log units) below the measured one; measured number inside the range.
By their numbers in this assay, from the lowest: compound 2; then compound 4; then compound 3.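

For the compounds shown here, compounds 2 and 4 form the first pair here that differs in one place. On a saturated chain carbon, two bonds along the chain from an amine nitrogen in a ring, replacing the group with one double bond by 2,3-dihydro-1H-inden-2-yl gives a 3.9-fold higher number from compound 2 to compound 4 (0.59 log units; beyond the scatter) in this assay. So the two groups, although equal in heavy atoms, are not interchangeable at this position, yet the step is only modest. Nothing measured here explains this step.

Going by these compounds, what an amine or a hydroxyl group on the 2,3-dihydro-1H-inden-2-yl group would do remains open. One pair also cannot show whether this change would have a similar effect on another core.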